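Aryl swap on the ring nitrogen of compound 2

The source may hold more compounds than are shown below. What is called first, only, known or untested is meant among the compounds shown, and "the series" means these compounds.

Two compounds have numbers in a functional assay on HEK293 cells for negative allosteric modulation of metabotropic glutamate receptor 5 (Homo sapiens), read by FLIPR and calcium flux; a higher number here means a weaker inhibitor, a lower number a stronger inhibitor. Compound 1 `Cc1c(C(=O)Nc2ccncc2)nn(C)c1-c1ccc(F)cc1` gives 301 nM. Compound 2 `Cc1cccc(NC(=O)c2nc(C)n(-c3ccc(Cl)c(Cl)c3)c2C)n1` gives 5.8 nM, the lower of the two and beyond the scatter from compound 1; the two differ in more than one place, so only their values can be set side by side. Compound 3 `COc1ccc(-n2c(C)nc(C(=O)Nc3cccc(C)n3)c2C)cc1` is not yet measured. It differs from compound 2 by 4-methoxyphenyl in place of 3,4-dichlorophenyl on an aromatic nitrogen. Among the measured compounds shown here, no pair of measured compounds shows this swap alone, so its size has no anchor in the measured set. A rise in the half-maximal inhibitory concentration beyond the scatter is expected, amounting to a 6.0-fold higher number from compound 2 to compound 3 (0.78 log units; beyond the scatter). Compound 3 is expected to give 35 nM in this assay, with a range from 8 nM to 160 nM.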

Compound 3, half-maximal inhibitory concentration: 147 nM
Beside the measured number, compound 3's estimate is 4.2-fold (0.62 log units) below it; the measured number falls inside the stated range.
By their numbers in this assay, from the lowest: compound 2; then compound 3; then compound 1.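

In this assay, among the compounds shown here, the aryl group on the aromatic nitrogen proves to be a strong determinant of the value: 4-methoxyphenyl in place of 3,4-dichlorophenyl gives a 25-fold higher number from compound 2 to compound 3 (1.40 log units; beyond the scatter) and is the first single-place change. The size of the step is large even though both groups have 8 heavy atoms and one six-membered aromatic ring of carbon only; the counted differences are the chlorine atoms leaving and an oxygen and a hydrogen-bond acceptor entering. No measurement at hand explains the step.

The swap removes both chlorines and adds the methoxy group at once, so the contribution of each remains unresolved. On these data alone, whether 4-chlorophenyl or plain phenyl on this nitrogen would sit nearer compound 2 or compound 3 also stays open.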